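Swapping the Ether Substituent: Saturated Ring to Phenethyl

This account rests on a few compounds, and the source may have more. Where it says the series, first, only, none or still open, it means among the compounds named here.

Measured so far in an assay on cells for binding affinity to Neuropeptide Y receptor type 1 (Homo sapiens); a lower number here means a stronger inhibitor, a higher number a weaker inhibitor:
Compound 1, `CCc1sc(CCc2cc(OC(CC)CC)cc(NCc3cc(Cl)cc(NC(=O)OC(C)C)c3)n2)nc1C`, gives 5.5 nM.
Compound 2, `CCc1sc(CCc2cc(OC3CCOCC3)cc(NCc3cc(Cl)cc(NC(=O)OC(C)C)c3)n2)nc1C`, gives 4.4 nM.

Among the measured compounds shown here, compound 2 has the lowest of the two numbers, but its only neighbour, compound 1, sits close: the step of a 1.3-fold lower number from compound 1 to compound 2 (0.10 log units; within the scatter) stays within the scatter, so the two cannot be told apart on these data. That step exchanged one group for another on the oxygen attached to the aromatic ring of the shared core, and the number barely moved.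

Compound 3, `CCc1sc(CCc2cc(OCCc3ccccc3)cc(NCc3cc(Cl)cc(NC(=O)OC(C)C)c3)n2)nc1C`, changes that same position again: phenethyl in place of oxan-4-yl on an oxygen on an aromatic ring. For the measured compounds named here, the group entering is larger than the one leaving and brings an aromatic ring rather than a saturated one, and no measured step covers such a change. Going by the values given here, the one step that bears on this position, from compound 1 to compound 2, was small, which suggests that this position tolerates different groups, but a single step is thin evidence.

Compound 3 is therefore expected to give a number near that of compound 2, with the step of a 1.4-fold higher number from compound 2 to compound 3 (0.13 log units; within the scatter) estimated to stay within or just beyond the scatter, in either direction. The estimate for compound 3 in this assay is 6 nM, with a range from 2 nM to 20 nM.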

Compound 3, half-maximal inhibitory concentration: 30 nM
For compound 3 the middle estimate is 5.0-fold (0.70 log units) below the measured one; the whole stated range lies below it.
By their numbers in this assay, from the lowest: compounds 2 and 1 (each within the scatter of the next); then compound 3.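

In this assay, phenethyl on the oxygen gives a 6.8-fold higher number from compound 2 to compound 3 (0.83 log units; beyond the scatter) and, set against pentan-3-yl, a 5.5-fold higher number from compound 1 to compound 3 (0.74 log units; beyond the scatter); this position therefore does not treat every group alike, which the small step between pentan-3-yl and oxan-4-yl alone could not reveal. Those two groups stay within the scatter of each other, whereas phenethyl, the only one of the three with an aromatic ring, gives a higher number than either, so the range of groups accepted here has a limit. Nothing among the data shown gives a reason for this rise in the number.

Phenethyl differs from the other two groups both in its aromatic ring and in the chain that links this ring to the oxygen, so these compounds cannot show which of the two features accounts for the step. On these data alone, a benzyl group, with a shorter link to the same ring, and a 2-cyclohexylethyl group, with the same link to a saturated ring, would pull those two features apart, and both remain open here.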